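The source may report more compounds than this note shows. Statements on the series, on what has been measured and on what is new or still open speak of the compounds shown alone.

Measured compounds in an assay for inhibition of 3-hydroxy-3-methylglutaryl-coenzyme A reductase (Rattus norvegicus), using microsomes; a lower number here means a stronger inhibitor, a higher number a weaker inhibitor:
compound 1 `COC(=O)C[C@H](O)C[C@H](O)/C=C/n1c(C(C)C)cc(-c2ccc(F)cc2)c1-c1ccc(F)cc1`: 2 nM
compound 2 `COC(=O)C[C@H](O)C[C@H](O)/C=C/n1c(C(C)C)cc(-c2ccncc2)c1-c1ccc(F)cc1`: 5 nM

Of these two numbers, compound 1 holds the lowest, the nearest being a 2.5-fold higher number from compound 1 to compound 2 (0.40 log units; beyond the scatter). Compound 3 `COC(=O)C[C@H](O)C[C@H](O)/C=C/n1c(C(C)C)cc(-c2ccc(F)cc2)c1-c1cccc(Cl)c1` differs from compound 1 by 3-chlorophenyl in place of 4-fluorophenyl on an aromatic carbon. Among the measured compounds shown here, the single measured step, a 2.5-fold higher number from compound 1 to compound 2 (0.40 log units; beyond the scatter), likewise exchanges a 4-fluorophenyl ring for another aromatic ring on the shared core and was modest, so in this assay a modest step upward, or none beyond the scatter, is expected: a 2.0-fold higher number from compound 1 to compound 3 (0.30 log units; within the scatter). Compound 3 is therefore estimated at 4 nM, with a range from 1.5 nM to 12 nM.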

Compound 3, half-maximal inhibitory concentration: 71 nM
For compound 3 the middle estimate is 18-fold (1.25 log units) below the measured one, outside the stated range (above it).
By their numbers in this assay, from the lowest: compound 1; then compound 2; then compound 3.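

In this assay, replacing 4-fluorophenyl with 3-chlorophenyl on the ring atom next to the ring nitrogen gives a 36-fold higher number from compound 1 to compound 3 (1.55 log units; beyond the scatter) even though both groups have the same heavy-atom count. That step is far larger than a 2.5-fold higher number from compound 1 to compound 2 (0.40 log units; beyond the scatter) at the neighbouring ring atom that bears a 4-fluorophenyl group, so the two aromatic positions do not respond alike to these changes.

As far as these compounds go, because the halogen and its ring position change together, it remains open which matters, and 4-chlorophenyl or 3-fluorophenyl at this position would separate them. No supporting evidence is available to explain the large step.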